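Spiro series: amide end-group change toward methylsulfonylpiperazine

The source may hold more compounds than are shown below. What is called first, only, known or untested is meant among the compounds shown, and "the series" means these compounds.

Measured so far:
compound 1 `CC(C)(C)c1ccc(C(=O)N2CCC3(CC2)C(=O)N(CC(=O)N2CCC(CCO)CC2)CN3c2ccccc2)cc1` — 2600 nM
compound 2 `CC(C)(C)OC(=O)NC1CCN(C(=O)CN2CN(c3ccccc3)C3(CCN(C(=O)c4ccc(C(C)(C)C)cc4)CC3)C2=O)CC1` — 8300 nM

Both numbers come from an assay on HEK293 cells for displacement of a labelled ligand from NPC1-like intracellular cholesterol transporter 1 (Homo sapiens); a higher number here means a weaker inhibitor, a lower number a stronger inhibitor. Compound 1 holds the lowest of the two numbers in this assay; its nearest neighbour is compound 2, and the change between them, (tert-butoxycarbonyl)amino in place of 2-hydroxyethyl on a saturated ring carbon, gives a 3.2-fold higher number from compound 1 to compound 2 (0.50 log units; beyond the scatter).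

Compound 3 `CC(C)(C)c1ccc(C(=O)N2CCC3(CC2)C(=O)N(CC(=O)N2CCN(S(C)(=O)=O)CC2)CN3c2ccccc2)cc1` is not yet measured. It differs from compound 1 by 4-(methylsulfonyl)piperazin-1-yl in place of 4-(2-hydroxyethyl)piperidin-1-yl on a carbonyl carbon. Going by the values given here, this exchanges the whole terminal ring rather than only the substituent on it, so the one measured step bears on it only loosely: that step, a 3.2-fold higher number from compound 1 to compound 2 (0.50 log units; beyond the scatter), shows that altering the group carried by the terminal ring in this region moves the number by a modest amount, in the weakening direction. On that basis compound 3 is expected to show a modest step in the same direction, about a 1.9-fold higher number from compound 1 to compound 3 (0.28 log units; within the scatter), with a wide range because no other variation at this position has been measured.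

For compound 3 the estimated value is 5000 nM, within 2000 nM to 12000 nM.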

Compound 3, half-maximal inhibitory concentration: 19000 nM
For compound 3 the middle estimate is 3.8-fold (0.58 log units) below the measured one; measured number outside the range, above it.
By their numbers in this assay, from the lowest: compound 1; then compound 2; then compound 3.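

In this assay, exchanging the terminal ring on the carbonyl carbon gives a 7.3-fold higher number from compound 1 to compound 3 (0.86 log units; beyond the scatter), so a change at this position need not stay small, even though the leaving and entering groups are both six-membered non-aromatic rings with no net charge. Together with a 3.2-fold higher number from compound 1 to compound 2 (0.50 log units; beyond the scatter), this leaves compound 1, with its 4-(2-hydroxyethyl)piperidin-1-yl group, holding the lowest number of the three, and both changes at this position run in the same direction. No supporting data bear on why the number rises with this exchange.

The exchange alters the ring and its substituent in one step, so the compounds shown leave open whether the second ring nitrogen, the methylsulfonyl group or the departure of the 2-hydroxyethyl group accounts for the step. A 4-(methylsulfonyl)piperidin-1-yl group and a piperazine carrying 2-hydroxyethyl on nitrogen would separate these, while a carboxylic acid or a primary amine on the terminal ring also remains an open question for this position.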